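The source may hold more compounds than are shown below. What is called first, only, known or untested is meant among the compounds shown, and "the series" means these compounds.

Measured so far in a functional assay on HOP-62 cells (Homo sapiens) for inhibition, read by sulforhodamine B assay, with a stated time of 48 h; on this read-out lower numbers stand for stronger inhibition of growth and higher numbers for weaker inhibition of growth:
- Compound 1 `O=C(Nc1cccc(-n2cc(-c3ccncc3)c(-c3ccc(Cl)c(O)c3)n2)c1)Nc1cccc(C(F)(F)F)c1`: > 32500 nM
- Compound 2 `COc1cc(-c2nn(-c3cccc(NC(=O)Nc4ccc(Cl)c(Cl)c4)c3)cc2-c2ccncc2)ccc1Cl`: 4900 nM

The reading of compound 1, > 32500 nM, is a limit and not a number. This leaves compound 1 without an exact place on the scale. Compound 2, by contrast, has a true number, 4900 nM.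

The next compound to be tested is compound 3 `COc1cc(-c2nn(-c3cccc(NC(=O)Nc4cccc(C(F)(F)F)c4)c3)cc2-c2ccncc2)ccc1Cl`. It is compound 1 with a single change: methyl in place of hydrogen on an oxygen on an aromatic ring. Methyl takes the place of hydrogen on an oxygen on an aromatic ring, so 4-chloro-3-hydroxyphenyl becomes 4-chloro-3-methoxyphenyl.

For the measured compounds named here, no measured pair of compounds shows this change alone, so its size cannot be read directly from the data. The best available guide is compound 2, which also carries the 4-chloro-3-methoxyphenyl group and gives 4900 nM. On that basis, a move towards stronger inhibition of growth in this assay is expected, beyond the usual scatter. The estimated size of this move is an at least 4.6-fold lower number from compound 1 to compound 3 (0.66 log units; beyond the scatter), and it remains rough. Compound 3 is expected to read about 7000 nM, with an estimated range of 2500 nM to 25000 nM.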

Compound 3, concentration for total growth inhibition: 4070 nM
Beside the measured number, compound 3's estimate is 1.7-fold (0.24 log units) above it, within the range that was stated.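

In this assay, replacing the hydrogen of the hydroxy group with methyl gives an at least 7.9-fold lower number from compound 1 to compound 3 (0.90 log units; beyond the scatter), the first direct view of what this one change does at this oxygen on the aromatic ring. Compound 1 has only a limit, so the full size of that step cannot be read: the limit of > 32500 nM in this assay, at which 1 of the 3 values shown sits.

With the methoxy group in place, exchanging the group on the amide-type nitrogen gives a 1.2-fold lower number from compound 2 to compound 3 (0.08 log units; within the scatter), which lies within the scatter; 3-(trifluoromethyl)phenyl and 3,4-dichlorophenyl therefore cannot be told apart here, and the large step from the hydroxy compound goes with the change at the oxygen, not with the 3-(trifluoromethyl)phenyl group.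

The compounds shown leave open whether a longer chain on this oxygen, such as ethyl, or an amine in place of the hydroxy group, would read like the methoxy group of compound 3. They also leave open whether hydroxy to methoxy gives a step of similar size when 3,4-dichlorophenyl sits on the amide-type nitrogen, and they give no measured reason for the step.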